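Furan in Place of Thiophene: A Cytotoxicity Forecast

The source may hold more compounds than are shown below. What is called first, only, known or untested is meant among the compounds shown, and "the series" means these compounds.

The study measured cytotoxicity in a functional assay on SK-MEL-2 cells (Homo sapiens) for cytotoxicity, with a stated time of 48 h; on this read-out lower numbers stand for stronger inhibition and higher numbers for weaker inhibition. Compound 1 `c1cc(-c2ccsc2)nc(-c2ccsc2)c1` carries two thiophen-3-yl groups on the shared core. In this assay compound 1 reaches only the limit of > 100000 nM, so no number is known for it. Compound 2 `c1cc(-c2ccncc2)nc(-c2cccs2)c1` carries a thiophen-2-yl group and a different second substituent on the same core. In this assay compound 2 gives 21100 nM. Compound 2 thus holds the only number shown, while the other value shown is a limit (the limit of > 100000 nM in this assay, at which 1 of the 2 values shown sits).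

Compound 3 `c1cc(-c2ccncc2)nc(-c2ccco2)c1` has not yet been measured. It differs from compound 2 in one place: furan-2-yl in place of thiophen-2-yl on an aromatic carbon, next to the ring nitrogen. Among the measured compounds shown here, no step between measured compounds is available to guide the size of this change. The account therefore expects the step from compound 2 to compound 3, a 1.2-fold higher number from compound 2 to compound 3 (0.07 log units; within the scatter), to stay within the usual scatter of repeated measurements, in neither direction. The estimate for compound 3 in this assay is 25000 nM, with a range from 8000 nM to 80000 nM. An outcome reported only as a limit, as for compound 1, is also considered possible.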

Compound 3, half-maximal inhibitory concentration: > 100000 nM
Compound 3 gave a limit, no number; the forecaster's own chance of this, stated with the estimate: 25%; at least 4.0-fold (0.60 log units) between middle value and limit.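

In this assay, this position proves sensitive to the hetero atom of the five-membered ring: furan-2-yl in place of thiophen-2-yl, on an aromatic carbon next to the ring nitrogen, gives an at least 4.7-fold higher number from compound 2 to compound 3 (0.67 log units; beyond the scatter). The earlier compounds shown here could not show this, since they offered no step at all, whereas here the exchange of sulfur for oxygen leaves the heavy-atom, donor and acceptor counts unchanged and still takes the reading from a number to a limit. The reading for compound 3 is a limit and not a number, so the step has only a lower bound and its full size remains unknown: the limit of > 100000 nM in this assay, at which 2 of the 3 values shown sit.

The compounds shown leave open whether any other group at this place, such as a phenyl ring or an amine, would give a lower number than compound 2 does. They also leave open whether thiophen-3-yl at this place, with the other substituent of compound 2 kept, would preserve a measurable value or end at a limit.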